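Moving the acid and fluorine on compound 1

This account rests on a few compounds, and the source may have more. Where it says the series, first, only, none or still open, it means among the compounds named here.

Largest response in an assay on HEK293 cells for positive allosteric modulation of metabotropic glutamate receptor 3 (Rattus norvegicus), read by thallium flux, with a stated time of 2.5 min; on this read-out higher numbers stand for larger maximal responses and lower numbers for smaller maximal responses:
Compound 1 `Cc1c(OCCCCOc2ccc(C(=O)O)cc2F)ccc(C(=O)CC2CCCC2)c1O`: 31.2%
Compound 2 `COC(=O)c1ccc(OCCCCOc2ccc(C(=O)CC3CCCC3)c(C)c2C)cc1`: 24.2%
Compound 3 `Cc1c(OCCCCOc2ccc(C(=O)O)cc2F)ccc(C(=O)CC(C)C)c1O`: 67.7%

Compound 1 stands second highest of these three numbers; its value lies within the scatter of compound 2, while compound 3 sits well above it, as a number 36.5 percentage points higher from compound 1 to compound 3 (beyond the scatter) shows. Compound 4 `Cc1c(OCCCCOc2ccc(F)c(C(=O)O)c2)ccc(C(=O)CC2CCCC2)c1O` has the same atoms as compound 1, joined differently: 3-carboxy-4-fluorophenyl in place of 4-carboxy-2-fluorophenyl on an oxygen on a saturated carbon. Within the data shown here, the only measured step, a number 36.5 percentage points higher from compound 1 to compound 3 (beyond the scatter), altered the group on the saturated chain carbon bound to the carbonyl carbon, not the 4-carboxy-2-fluorophenyl group, so no measured step bears on this change. With nothing pointing either way, no step beyond the scatter is expected in this assay. Compound 4 is therefore expected to give about 31%, between 15% and 50%. That amounts to an expected step of a number 0.2 percentage points lower from compound 1 to compound 4 (within the scatter).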

Compound 4, largest response reached (reported as percent of maximum), in percent of the reference or control that the assay uses: 98.4%
Estimate against measurement, compound 4: 67.4 percentage points below; measured number above the stated range.
By their numbers in this assay, from the lowest: compounds 2 and 1 (each within the scatter of the next); then compound 3; then compound 4.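

Rearranging the same atoms on the ring carried by the oxygen is enough to alter the response in this assay: 3-carboxy-4-fluorophenyl in place of 4-carboxy-2-fluorophenyl gives a number 67.2 percentage points higher from compound 1 to compound 4 (beyond the scatter). Among these compounds, the earlier step showed only that the group on the saturated chain carbon matters; this aromatic group matters as well. Nothing measured here gives a reason for this step.

Both the carboxylic acid and the fluorine move in this change, so the compounds shown leave open which of them accounts for it. Also open, as far as these compounds go, is how a 3-carboxyphenyl group without fluorine, or a tetrazole in place of the carboxylic acid, would behave.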